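The source may report more compounds than this note shows. Statements on the series, on what has been measured and on what is new or still open speak of the compounds shown alone.

Of the compounds shown here, three have so far been measured in an assay on HEK293 cells for displacement of a labelled ligand from Translocator protein (Homo sapiens), read by scintillation counting, with a stated time of 90 min; a lower number here means a stronger inhibitor, a higher number a weaker inhibitor. Compound 1 `CN(Cc1ccccc1)C(=O)c1nc2ccccc2n1Cc1ccc(Cl)cc1` gives > 10000 nM, which is a limit of this assay rather than a number (the limit of > 10000 nM in this assay, at which 1 of the 3 values shown sits). Compound 2 `C#CCN(C)C(=O)c1cc2cc(NS(C)(=O)=O)ccc2n1Cc1ccc(OC)cc1` gives 761 nM in this assay. Compound 3 `CC(=O)N(Cc1ccccc1)c1cc(C)cc(C)c1` gives 1260 nM in this assay, and the gap between compound 3 and compound 2 lies within the usual scatter, so these two cannot be told apart on the numbers shown. Within the data shown here, no pair of measured compounds differs in only one place, so no measured step is available to lean on. Compound 4 `CC(=O)N(Cc1ccc(OCCF)cc1)c1cc(C)cc(C)c1` differs from compound 3 by 2-fluoroethoxy in place of hydrogen on an aromatic carbon. Among the measured compounds shown here, with no measured step of this kind, the expectation rests on the size and nature of the added group alone. The step is estimated to be a 3.2-fold lower number from compound 3 to compound 4 (0.50 log units; beyond the scatter), a modest move towards a stronger inhibitor that may still sit near the edge of the scatter. Compound 4 is therefore expected to give about 400 nM in this assay, with a plausible range from 100 nM to 1500 nM.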

Compound 4, inhibition constant: 3930 nM
Estimate against measurement, compound 4: 9.8-fold (0.99 log units) below; measured number above the stated range.
By their numbers in this assay, from the lowest: compounds 2 and 3 (each within the scatter of the next); then compound 4. At a limit, above all of these: compound 1.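

In this assay, 2-fluoroethoxy in place of hydrogen on an aromatic carbon, para to a large group, gives a 3.1-fold higher number from compound 3 to compound 4 (0.49 log units; beyond the scatter), so the added group moves this series towards a weaker inhibitor. This is the first measured step among these compounds, and it shows that this position is not indifferent to substitution. The only limit among the compounds shown belongs to compound 1, and compound 4 still gives a number rather than reaching that limit: the limit of > 10000 nM in this assay, at which 1 of the 4 values shown sits.

One group at one position cannot separate the contribution of the linking oxygen from that of the fluorine-bearing chain, which would take comparison with a methoxy group, a single fluorine atom or a longer chain on the same carbon. Why the number rises remains open, as does how an amine or a carboxylic acid would behave at this position.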